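A few compounds are considered here, and "the series" means these few. Any claim that something is new, unique, unknown or untested is made for them only; others in the source may bear on it.

Measured so far:
- compound 1 `CCn1ccc2cc(Cc3ccc(OC)c(OC)c3OC)ccc21`: > 1000 nM (a limit, not a number)
- compound 2 `COc1ccc(C(O)c2ccc3c(ccn3C)c2)c(OC)c1OC`: 2500 nM

Among the compounds with values here, in a functional assay on HeLa cells (Homo sapiens) for cytotoxicity, read by XTT assay, with a stated time of 72 h (on this read-out higher numbers stand for weaker inhibition and lower numbers for stronger inhibition), compound 2 gives 2500 nM, the only actual number so far. Compound 1 is reported only as a limit, > 1000 nM. Within the data shown here, with just these two entries, there is no measured step to calibrate against, and compound 2 cannot yet be placed within any range of activity.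

The next compound is compound 3 `CCn1ccc2cc(C(O)c3ccc(OC)c(OC)c3OC)ccc21`. Its change from compound 2 is small: methyl in place of hydrogen on a saturated chain carbon bound to an aromatic nitrogen. In words, this is methyl in place of hydrogen on a saturated chain carbon bound to an aromatic nitrogen, which turns methyl into ethyl.

The expectation rests on compound 2 at 2500 nM and on the small size of this change. In this assay the expected step of a 1.2-fold higher number from compound 2 to compound 3 (0.08 log units; within the scatter) is small, with no firm direction and nothing expected beyond the usual scatter. A report of a limit instead of a number also remains possible. For compound 3 the estimated value is 3000 nM, with an expected range from 1000 nM to 9000 nM.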

Compound 3, half-maximal inhibitory concentration: < 1000 nM
Compound 3: only a limit was reported; the forecaster's own chance of this, stated with the estimate: 30%; middle value at least 3.0-fold (0.47 log units) from the limit.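

Working notes on the series: in this assay, methyl in place of hydrogen on a saturated chain carbon bound to an aromatic nitrogen, which turns methyl into ethyl, gives an at least 2.5-fold lower number from compound 2 to compound 3 (0.39 log units; beyond the scatter) and so provides the first measured step in the series. The earlier compounds shown here offered no such comparison. Compound 3 is reported only as a limit (< 1000 nM), not as a number. The other new step, hydroxy in place of hydrogen on a saturated chain carbon bound to two aromatic carbons, gives a number no higher from compound 1 to compound 3 (the limit leaves the size open) and cannot be read for size, and nothing given here bears on a cause for either step.

From the compounds shown here alone, the actual value of compound 3 remains open, and with it the full size of the gain from methyl to ethyl. Also open, going by these compounds, is whether a longer chain, such as propyl or butyl, or a chain ending in an amine or a carboxylic acid, would continue or reverse this step in this assay at the same place.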